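Cytotoxicity estimate for a ring nitrogen in compound 3

The source may report more compounds than this note shows. Statements on the series, on what has been measured and on what is new or still open speak of the compounds shown alone.

Measured so far:
compound 1, `Nc1cccc(-c2cc(Nc3ccc(OC(F)(F)F)cc3)ncn2)c1`: > 10000 nM
compound 2, `FC(F)(F)Oc1ccc(Nc2cc(-c3cccc4[nH]ccc34)ncn2)cc1`: 3790 nM

Compound 1 gives only a limit in an ADME assay on BaF3 cells (Mus musculus) for cytotoxicity (on this read-out lower numbers stand for an effect already at smaller amounts and higher numbers for an effect only at larger amounts of compound), so compound 2 holds the sole number shown. Among the compounds with values here, the single measured step, an at least 2.6-fold lower number from compound 1 to compound 2 (0.42 log units; beyond the scatter), concerns a different change at the same carbon and does not speak to the present one. Compound 3, `FC(F)(F)Oc1ccc(Nc2cc(-c3ccnc4[nH]ccc34)ncn2)cc1`, differs from compound 2 by a group of 9 heavy atoms (7 carbon, 2 nitrogen; one five-membered aromatic ring with 1 hetero atom, one six-membered aromatic ring with 1 hetero atom) in place of a group of 9 heavy atoms (8 carbon, 1 nitrogen; one five-membered aromatic ring with 1 hetero atom, one six-membered aromatic ring of carbon only), on an aromatic carbon. Within the data shown here, no step informs this exchange, so compound 3 is expected to stay near compound 2, with a 1.2-fold higher number from compound 2 to compound 3 (0.07 log units; within the scatter) within the scatter; its estimate is 4500 nM, between 1800 nM and 10000 nM.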

Compound 3, half-maximal effective concentration: 6850 nM
The estimate for compound 3 lay 1.5-fold (0.18 log units) below the measured number; low and high end bracket the measured number.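

In this assay, exchanging 1H-indol-4-yl for the group with a nitrogen in its six-membered aromatic ring gives a 1.8-fold higher number from compound 2 to compound 3 (0.26 log units; within the scatter). At this position, then, that added ring nitrogen does not separate compound 2 from compound 3. The comparison with the 3-aminophenyl compound gives an at least 1.4-fold lower number from compound 1 to compound 3 (0.16 log units; that floor lies within the scatter), and it rests on a limit: the limit of > 10000 nM in this assay, at which 1 of the 3 values shown sits.

On these data alone, whether a methoxy group or an amine on the 1H-indol-4-yl group would move the number beyond the scatter remains open. So does the effect of replacing the trifluoromethoxy group with a chlorine atom.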